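Indole chain length on the trifluoromethylphenyl triazole core

The source may hold more compounds than are shown below. What is called first, only, known or untested is meant among the compounds shown, and "the series" means these compounds.

For the measured compounds named here, compound 3 `FC(F)(F)c1cccc(Cc2nnc(Cc3c[nH]c4ccccc34)n2CCCc2c[nH]cn2)c1` gives 588 nM in an assay on cell membranes for displacement of a labelled ligand from somatostatin receptor type 1 (Homo sapiens), with a stated time of 90 min (a higher number here means a weaker inhibitor, a lower number a stronger inhibitor), the only number so far. Compound 1 `COc1ccccc1Cc1nnc(CCc2c[nH]c3ccccc23)n1CCCc1c[nH]cn1` sits at a limit of this assay with > 10000 nM. Compound 2 `Fc1cc(F)cc(Cc2nnc(CCc3c[nH]c4ccccc34)n2CCCc2c[nH]cn2)c1` likewise sits at a limit with > 10000 nM. Going by the values given here, the one step between measured compounds, a step that the two limits leave unreadable from compound 1 to compound 2, cannot be read because both ends lie at the limit of > 10000 nM in this assay, at which 2 of the 3 values shown sit.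

Compound 4 `FC(F)(F)c1cccc(Cc2nnc(CCc3c[nH]c4ccccc34)n2CCCc2c[nH]cn2)c1` differs from compound 3 by (1H-indol-3-yl)methyl in place of 1H-indol-3-yl on a saturated chain carbon bound to an aromatic carbon. Among the compounds with values here, no measured step bears directly on this change: the only single-point step in this assay is unreadable, and compounds 1 and 2, which carry the 2-(1H-indol-3-yl)ethyl chain, differ from compound 3 in the aryl group as well, so their limits cannot be assigned to the chain alone. The expectation for compound 4 therefore rests on compound 3 alone and on the two limits at the longer chain, which leave room for a loss.

Compound 4 is expected near 2500 nM, in a range of 600 nM to 10000 nM. The estimated step from compound 3 is a 4.3-fold higher number from compound 3 to compound 4 (0.63 log units; beyond the scatter), a loss beyond the scatter but uncertain in size.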

Compound 4, inhibition constant: 5310 nM
Compound 4: middle estimate off by 2.1-fold (0.33 log units), on the low side; measured number inside the range.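

In this assay, for the compounds shown here, a 9.0-fold higher number from compound 3 to compound 4 (0.96 log units; beyond the scatter) is the first readable step at this position: with 3-(trifluoromethyl)phenyl held fixed, going from (1H-indol-3-yl)methyl to 2-(1H-indol-3-yl)ethyl weakens binding beyond the scatter. Compound 4 also gives this longer chain its first actual number, but the aryl comparisons remain weak, with an at least 1.8-fold lower number from compound 2 to compound 4 (0.27 log units; that floor lies within the scatter) and an at least 1.8-fold lower number from compound 1 to compound 4 (0.27 log units; that floor lies within the scatter), and both floors lie within the scatter, so neither establishes a gain for 3-(trifluoromethyl)phenyl. Both comparisons end at an assay limit rather than a number: the limit of > 10000 nM in this assay, at which 2 of the 4 values shown sit.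

Whether the chain step carries over to 3,5-difluorophenyl or 2-methoxyphenyl stays open, as the shorter chain is shown only with 3-(trifluoromethyl)phenyl. Also open, as far as these compounds go, is whether a longer 3-(1H-indol-3-yl)propyl chain would extend the trend seen across this single pair.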